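The compounds below may be only part of what the source reports. "The series", "measured", "known", "first", "only" and "open" are said of these compounds alone.

Measured so far:
Compound 1 `CCCCC1CCC(OC(=O)N[C@@H](CC(C)C)C(=O)N[C@H](C=O)C[C@@H]2CCNC2=O)CC1` gives 63300 nM in a toxicity assay on L929 cells (Mus musculus) for cytotoxicity; a lower number here means that less compound is tolerated, a higher number that more compound is tolerated.
Compound 2 `CCCCC1CCC(OC(=O)N[C@@H](CC(C)C)C(=O)N[C@@H](C[C@@H]2CCNC2=O)C(O)S(=O)(=O)O)CC1` gives 59100 nM in this assay.

On these two numbers compound 2 stands within the usual scatter of compound 1: the step of a 1.1-fold lower number from compound 1 to compound 2 (0.03 log units; within the scatter) is too small to count as a real change. Compound 3 `CC(C)C[C@H](NC(=O)OC1CCCCC1)C(=O)N[C@@H](C[C@@H]1CCNC1=O)C(O)S(=O)(=O)O` is the next compound to be measured in this assay. It differs from compound 2 in one place: hydrogen in place of butyl on a saturated ring carbon. For the measured compounds named here, the single measured step, a 1.1-fold lower number from compound 1 to compound 2 (0.03 log units; within the scatter), put hydroxy(sulfo)methyl in place of formyl at a different site and so tells nothing about what taking away the butyl does; no measured step bears on this change. With no such comparison at hand, the expected step of a 1.1-fold higher number from compound 2 to compound 3 (0.04 log units; within the scatter) in this assay is taken as nothing beyond the scatter, in no preferred direction. Compound 3 is accordingly estimated at 65000 nM in this assay, with a range from 25000 nM to 170000 nM.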

Compound 3, half-maximal cytotoxic concentration: > 100000 nM
Compound 3 gave a limit, no number (the forecaster's own chance of this, stated with the estimate: 25%); middle value at least 1.5-fold (0.18 log units) away from the limit.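

For compound 3 the read-out in this assay is a limit and not a number: the limit of > 100000 nM in this assay, at which 1 of the 3 values shown sits. Hydrogen in place of butyl, on a saturated ring carbon three ring bonds from the ring atom that bears a large group, gives an at least 1.6-fold higher number from compound 2 to compound 3 (0.22 log units; that floor lies within the scatter), so this step fixes only a floor, and that floor does not itself pass beyond the scatter. For the compounds shown here, this is the first reading at this position, and it shows that removing the butyl brings no lower number, while the true size of the step stays unknown.

The compounds shown leave open how a methyl, a longer chain or an amine on this ring carbon would read. They also leave open how hydrogen at this carbon would read with the formyl of compound 1 in place of the hydroxy(sulfo)methyl.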